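A stereocentre left undefined: from compound 2 to compound 3

A few compounds are considered here, and "the series" means these few. Any claim that something is new, unique, unknown or untested is made for them only; others in the source may bear on it.

Compound 1 `CC(=O)CC[C@@H]1[C@H]([C@H]2C(=O)CC[C@]2(C)[C@H](CC(C)C)c2c(O)c(C=O)c(O)c(C=O)c2O)C1(C)C` and compound 2 `CC(C)C[C@H](c1c(O)c(C=O)c(O)c(C=O)c1O)[C@@]1(C)CC[C@H]2C1=C[C@H](C(C)(C)O)CC[C@H]2C` share the same core and were both tested in a functional assay on HL-60 cells (Homo sapiens) for cytotoxicity, read by MTT assay, with a stated time of 72 h; on this read-out lower numbers stand for stronger inhibition and higher numbers for weaker inhibition. In this assay compound 1 gives < 10000 nM, which is a limit of the assay rather than a number. In this assay compound 2 gives < 10000 nM, again a limit and not a number. Compound 2 therefore stands at the limit of < 10000 nM in this assay, at which 2 of the 2 values shown sit, and nothing separates it from compound 1 beyond that shared limit. Compound 3 `CC(C)CC(c1c(O)c(C=O)c(O)c(C=O)c1O)[C@@]1(C)CC[C@H]2C1=C[C@H](C(C)(C)O)CC[C@H]2C` has not yet been measured. It differs from compound 2 as follows: the two compounds have the same atoms and bonds; at least one stereo element is drawn with a configuration in one of them and without one in the other: 1 of 5 stereo elements differ; a stereocentre at a saturated chain carbon is drawn S in compound 2 and without a configuration in compound 3. Within the data shown here, no step between measured compounds exists here to lean on. With the same atoms and bonds and only one stereocentre drawn differently, the expectation for compound 3 is no change beyond the usual scatter, expressed as the step that the limit leaves unreadable from compound 2 to compound 3. Compound 3 is accordingly estimated at 3000 nM, within 300 nM to 10000 nM, and it may well return only a limit once more.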

Compound 3, half-maximal inhibitory concentration: < 10000 nM
Compound 3: only a limit was reported; the forecaster's own chance of this, stated with the estimate: 65%; the middle value lies beyond the limit too.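

Among these compounds, compound 2 and compound 3 both sit at a limit of the assay rather than at a number, so no step between them can be read. The compounds shown leave open the actual value of each, and whether the configuration at the saturated chain carbon matters: the limit of < 10000 nM in this assay, at which 3 of the 3 values shown sit.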